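Cyclopentene diaryl acids: replacing a carboxypyrimidinyl by carboxyphenyl

The source may report more compounds than this note shows. Statements on the series, on what has been measured and on what is new or still open speak of the compounds shown alone.

Measured compounds:
compound 1 `CSc1ccc(OCc2ccc(F)cc2F)c(C2=C(c3cccc(C(=O)O)c3)CCC2)c1`, 15.9 nM
compound 2 `O=C(O)c1cc(C2=C(c3cc(Cl)ccc3OCc3ccccc3)CCC2)ncn1`, 200 nM
compound 3 `O=C(O)c1cncc(C2=C(c3cc(C(F)(F)F)ccc3OCc3ccccc3)CCC2)c1`, 10 nM

In an assay on isolated protein for inhibition of prostaglandin E2 receptor EP1 subtype (Homo sapiens) (a lower number here means a stronger inhibitor, a higher number a weaker inhibitor), compound 2 gives 200 nM, the highest of the three numbers on hand. Compound 1 gives 15.9 nM and compound 3 gives 10 nM; both gaps to compound 2 lie beyond the usual scatter. No pair among these three differs in only one place, so no single step can be read off directly.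

The unmeasured compound 4 `O=C(O)c1cccc(C2=C(c3cc(Cl)ccc3OCc3ccccc3)CCC2)c1` is derived from compound 2 by one change: 3-carboxyphenyl in place of 6-carboxypyrimidin-4-yl on a double-bonded ring carbon. Compound 1 carries the same 3-carboxyphenyl group, though it differs from compound 2 elsewhere as well, and compound 1 in this assay sits well below compound 2.

Expectation: the step from compound 2 to compound 4 is estimated as a decrease in the number beyond the scatter, a 6.7-fold lower number from compound 2 to compound 4 (0.82 log units; beyond the scatter), because compound 1 with 15.9 nM and compound 3 with 10 nM both lie far below compound 2. For compound 4 the expected value in this assay is 30 nM, with a range from 8 nM to 120 nM.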

Compound 4, half-maximal inhibitory concentration: 5.01 nM
Compound 4: middle estimate off by 6.0-fold (0.78 log units), on the high side; the whole stated range lies above it.
By their numbers in this assay, from the lowest: compounds 4, 3 and 1 (each within the scatter of the next, the first and the last beyond it); then compound 2.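

In this assay, a 40-fold lower number from compound 2 to compound 4 (1.60 log units; beyond the scatter) gives the series its first comparison that differs in one place, and the large step shows that the group on the double-bonded ring carbon strongly affects the number when the rest of compound 4 is held constant. The two groups have the same number of heavy atoms and each carries a carboxyl group, but 6-carboxypyrimidin-4-yl has 2 nitrogen atoms and 3 hydrogen-bond acceptors, whereas 3-carboxyphenyl has no ring nitrogen and 1 hydrogen-bond acceptor. No measurement on hand bears on why the step is this large, and it remains unassigned among these differences.

Steps linking compound 1 or compound 3 to the other compounds cannot be read, so it remains open whether 3-carboxyphenyl would give a similar step with a different group in place of the chlorine of compound 4, such as a nitrile or a methoxy group. Also open, as far as these compounds go, is how the number would respond if a tetrazole replaced the carboxylic acid on the 3-carboxyphenyl group of compound 4.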